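A few compounds are considered here, and "the series" means these few. Any claim that something is new, unique, unknown or untested is made for them only; others in the source may bear on it.

The measured compounds, with their results in a functional assay on KB cells (Homo sapiens) for cytotoxicity, read by sulforhodamine B assay; on this read-out higher numbers stand for weaker inhibition and lower numbers for stronger inhibition:

Compound 1, `C=C1[C@@H](C/C=C2/C(=O)OC[C@H]2OC(C)=O)[C@]2(C)CC[C@@H](OC(C)=O)[C@@](C)(CO[Si](C)(C)C(C)(C)C)[C@H]2C[C@@H]1O`: 9790 nM
Compound 2, `C=C1[C@@H](OC(C)=O)C[C@@H]2[C@](C)(COC=O)[C@H](OC(C)=O)CC[C@@]2(C)[C@@H]1C[C@@H](Nc1ccc(Br)cc1)C1=CCOC1=O`: 24000 nM
Compound 3, `C=C1[C@@H](OC(C)=O)C[C@@H]2[C@](C)(CO[Si](C)(C)C(C)(C)C)[C@H](OC(C)=O)CC[C@@]2(C)[C@@H]1C[C@@H](Nc1cccc2ccccc12)C1=CCOC1=O`: 8930 nM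

Compound 2 stands at the highest of the three numbers. Compound 1 lies a little lower, by an amount beyond the scatter, and compound 3 lies lower still, also beyond the scatter. No pair of these compounds differs in only one place, so none of the gaps between them can be tied to a single structural change.

Compound 4, `C=C1[C@@H](OC(C)=O)C[C@@H]2[C@](C)(COC=O)[C@H](OC(C)=O)CC[C@@]2(C)[C@@H]1C[C@@H](Nc1ccc(OC)cc1)C1=CCOC1=O`, has not yet been measured. It differs from compound 2 in one place: methoxy in place of bromo on an aromatic carbon.

Among the compounds with values here, because compound 2 itself sits at 24000 nM, and no measured step tells how this kind of exchange plays out on the shared core, the step from compound 2 to compound 4 in this assay is expected to be modest, most likely a somewhat lower number, and it may well remain within the scatter. On that basis compound 4 is estimated to give 18000 nM in this assay, with a range from 7000 nM to 45000 nM, and the step of a 1.3-fold lower number from compound 2 to compound 4 (0.12 log units; within the scatter) is the expectation that this estimate means.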

Compound 4, half-maximal inhibitory concentration: 32700 nM
Compound 4: the middle estimate sits 1.8-fold (0.26 log units) below what was measured; the measured number falls inside the stated range.
By their numbers in this assay, from the lowest: compounds 3 and 1 (each within the scatter of the next); then compounds 2 and 4 (each within the scatter of the next).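

This is the first step among these compounds that can be read at a single place. In this assay, methoxy in place of bromo on an aromatic carbon, para to a large group, gives a 1.4-fold higher number from compound 2 to compound 4 (0.13 log units; within the scatter), so at this position compound 2 and compound 4 cannot be told apart, although the exchange swaps one bromine for a carbon and an oxygen and brings in one hydrogen-bond acceptor. Nothing on hand bears on what lies behind this result.

What the compounds shown leave open is whether any other group at this place, such as a carboxylic acid, an amine or a nitrile, would shift the number beyond the scatter, since bromo and methoxy are the only two groups compared here on the same ring. As far as these compounds go, it also stays open whether the same exchange would read alike on another core, such as the core of compound 3, since this single step was read only on the shared core of compound 2 and compound 4.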